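The source may hold more compounds than are shown below. What is called first, only, known or untested is meant among the compounds shown, and "the series" means these compounds.

Working notes on the series. For the measured compounds named here, compound 1 `CCn1c(-c2ccccc2)nc2c(NC3CCC3)ncnc21` and compound 2 `Cn1c(-c2ccccc2)nc2c(NC3CCOC3)ncnc21` share one core and differ from each other in two places at once, so no single step between them can be isolated; their two numbers can only be set side by side. In an assay on CHO cells for displacement of a labelled ligand from adenosine receptor A1 (Homo sapiens), read by scintillation counting, with a stated time of 3 h (on this read-out higher numbers stand for weaker inhibition and lower numbers for stronger inhibition), compound 1 gives 6 nM. In this assay compound 2 gives 8 nM, which is where it stands among the two numbers, the gap to compound 1 being within the scatter of repeated measurements. Compound 3 `Cn1c(-c2ccccc2)nc2c(NC3CCC3)ncnc21` has not yet been measured in this assay. It is reached from compound 2 by one change: cyclobutyl in place of oxolan-3-yl on a nitrogen on an aromatic ring. Going by the values given here, no pair of measured compounds isolates this change, so its size cannot be read off directly. Compound 1, which already carries the cyclobutylamino group on this core, gives 6 nM, a number within the scatter of compound 2, and that gives no sign of a move beyond the scatter in either direction. The step from compound 2 to compound 3 is therefore expected to be small, a 1.3-fold lower number from compound 2 to compound 3 (0.12 log units; within the scatter), with no direction beyond the scatter. Compound 3 is estimated at 6 nM, within a range from 2 nM to 18 nM.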

Compound 3, inhibition constant: 3.2 nM
Estimate against measurement, compound 3: 1.9-fold (0.27 log units) above, within the range that was stated.
By their numbers in this assay, from the lowest: compounds 3, 1 and 2 (each within the scatter of the next, the first and the last beyond it).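

In this assay the change to cyclobutyl in place of oxolan-3-yl on a nitrogen on an aromatic ring now has a matched pair of its own (a 2.5-fold lower number from compound 2 to compound 3 (0.40 log units; beyond the scatter)), and this modest step lies beyond the scatter, which the side-by-side numbers of the two earlier compounds could not show. The second matched pair isolates hydrogen in place of methyl on a saturated chain carbon bound to an aromatic nitrogen (a 1.9-fold lower number from compound 1 to compound 3 (0.27 log units; within the scatter)), and this step stays within the scatter, so on the cyclobutylamino series no effect of that change can be told from repeat measurement. No measurement at hand bears on what lies behind the first step.

On these data alone, two compounds of one change give a single step, so it remains open whether the same step would hold with the longer chain on the aromatic nitrogen that compound 1 carries. Also open, as far as these compounds go, is how other groups on the amino nitrogen, such as cyclopentyl, piperidin-4-yl or an open propyl chain, would stand against cyclobutyl.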